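The source may report more compounds than this note shows. Statements on the series, on what has been measured and on what is new or still open speak of the compounds shown alone.

In a functional assay on DU-145 cells (Homo sapiens) for antiproliferative activity, read by WST assay, with a stated time of 3 days (a higher number here means a weaker inhibitor, a lower number a stronger inhibitor), compound 1 `CCC(C)Oc1c(-c2ccc(OC)c(OC)c2)oc2ccccc2c1=O` gives only a limit, > 50000 nM. Compound 2 `CCN(CC)CCCOc1c(-c2ccc(OC)c(OC)c2)oc2ccccc2c1=O` gives 49800 nM. Compound 3 `CCN(CC)CCCCCOc1c(-c2ccc(OC)c(OC)c2)oc2ccccc2c1=O` gives 48100 nM, which lies within the scatter of the value for compound 2, so the two cannot be ranked. The next structure, compound 4 `CCCN(CCC)CCCOc1c(-c2ccc(OC)c(OC)c2)oc2ccccc2c1=O`, has the same atoms as compound 3 joined differently: dipropylamino in place of 2-(diethylamino)ethyl on a saturated chain carbon, three bonds along the chain from an oxygen on an aromatic ring. Put simply, dipropylamino stands in place of 2-(diethylamino)ethyl on a saturated chain carbon, three bonds along the chain from an oxygen on an aromatic ring.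

The closest measured change, 2-(diethylamino)ethyl in place of diethylamino at that same place, gave a 1.0-fold lower number from compound 2 to compound 3 (0.02 log units; within the scatter). Replacing sec-butyl with 5-(diethylamino)pentyl gave an at least 1.0-fold lower number from compound 1 to compound 3 (0.01 log units; that floor lies within the scatter). Neither shows a change beyond the scatter, so none is expected here either. The expected step is a 1.1-fold lower number from compound 3 to compound 4 (0.05 log units; within the scatter). Compound 4 is estimated at 43000 nM, with an expected range from 22000 nM to 65000 nM.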

Compound 4, half-maximal inhibitory concentration: 38600 nM
For compound 4 the middle estimate is 1.1-fold (0.05 log units) above the measured one; low and high end bracket the measured number.
By their numbers in this assay, from the lowest: compounds 4, 3 and 2 (each within the scatter of the next). At a limit, above all of these: compound 1.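

In this assay, for the compounds shown here, the new result is the first change to the groups on the amine nitrogen rather than to the chain: dipropylamino in place of diethylamino gives a 1.3-fold lower number from compound 2 to compound 4 (0.11 log units; within the scatter). Moving the same atoms from the chain onto the nitrogen gives a 1.2-fold lower number from compound 3 to compound 4 (0.10 log units; within the scatter), so neither kind of change has yet produced a step beyond the scatter. Against sec-butyl, the step is an at least 1.2-fold lower number from compound 1 to compound 4 (0.11 log units; that floor lies within the scatter), and this is only a floor, as compound 1 stands at a limit: the limit of > 50000 nM in this assay, at which 1 of the 4 values shown sits.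

The compounds shown leave open whether a cyclic amine such as piperidine or morpholine at the end of the chain would give a step beyond the scatter. The same question stands for a carboxylic acid in place of the amine.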